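Tetrazolylmethyl in place of oxadiazolone on the shared core

This account rests on a few compounds, and the source may have more. Where it says the series, first, only, none or still open, it means among the compounds named here.

Three compounds share one core and differ only in the group on a saturated chain carbon bound to an aromatic carbon and a saturated chain carbon. Compound 1 `CC(C)C(c1ncc[nH]1)c1ccc(-c2ccc3cccc(F)c3c2)[nH]c1=O` gives 33 nM in a functional assay on CHO cells for antagonist activity at prostaglandin E2 receptor EP3 subtype (Homo sapiens), read by cAMP accumulation; on this read-out higher numbers stand for weaker inhibition and lower numbers for stronger inhibition. Compound 2 `CC(C)C(/C=C1\CCNC1=O)c1ccc(-c2ccc3cccc(F)c3c2)[nH]c1=O` gives 8.7 nM in this assay. Compound 3 `CC(C)C(c1noc(=O)[nH]1)c1ccc(-c2ccc3cccc(F)c3c2)[nH]c1=O` gives 41 nM in this assay and so carries the highest of the three numbers, though the step of a 1.2-fold higher number from compound 1 to compound 3 (0.09 log units; within the scatter) lies within the scatter, while the step of a 4.7-fold higher number from compound 2 to compound 3 (0.67 log units; beyond the scatter) lies beyond it.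

Compound 4 `CC(C)C(Cc1nnn[nH]1)c1ccc(-c2ccc3cccc(F)c3c2)[nH]c1=O` is not yet measured. It differs from compound 3 as follows: a group of 6 heavy atoms (2 carbon, 4 nitrogen; one five-membered aromatic ring with 4 hetero atoms) in place of a group of 6 heavy atoms (2 carbon, 2 nitrogen, 2 oxygen; one five-membered aromatic ring with 3 hetero atoms), on a saturated chain carbon bound to an aromatic carbon and a saturated chain carbon. The two measured steps that bear on this are the exchange of one aromatic five-membered ring for another, a 1.2-fold higher number from compound 1 to compound 3 (0.09 log units; within the scatter), which changed little, and the exchange of a non-aromatic ring for an aromatic one, a 4.7-fold higher number from compound 2 to compound 3 (0.67 log units; beyond the scatter), which was modest. Compound 4 again carries an aromatic five-membered ring at this position, now with a methylene in the path, and the two measured aromatic rings gave numbers close to each other. Compound 4 is therefore expected to show a step of a 1.2-fold lower number from compound 3 to compound 4 (0.07 log units; within the scatter), within the scatter. Compound 4 is estimated at 35 nM, with a range from 12 nM to 100 nM.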

Compound 4, half-maximal inhibitory concentration: 134 nM
The estimate for compound 4 lay 3.8-fold (0.58 log units) below the measured number; the whole stated range lies below it.
By their numbers in this assay, from the lowest: compound 2; then compounds 1 and 3 (each within the scatter of the next); then compound 4.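

In this assay, the (1H-tetrazol-5-yl)methyl group of compound 4 sets it apart from both compounds with an aromatic five-membered ring and no methylene, with a 3.3-fold higher number from compound 3 to compound 4 (0.51 log units; beyond the scatter) and a 4.1-fold higher number from compound 1 to compound 4 (0.61 log units; beyond the scatter), whereas a 1.2-fold higher number from compound 1 to compound 3 (0.09 log units; within the scatter) had stayed within the scatter. Having an aromatic five-membered ring on this saturated chain carbon is therefore not enough to keep the number near those of compound 1 and compound 3, since the group that enters here gives a number beyond the scatter of both. Among these compounds, the distance from the non-aromatic ring group also grows to a 15-fold higher number from compound 2 to compound 4 (1.19 log units; beyond the scatter), the only step in this set printed as large. No measurement is at hand that gives a reason for these differences.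

Compound 4 brings in a different ring and a methylene in a single change, so the compounds shown leave open how much of the step belongs to each. A 1H-tetrazol-5-yl group without the methylene, or a carboxylic acid or a longer chain carrying the tetrazole at this position, would bear on that question.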